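The source may report more compounds than this note shows. Statements on the series, on what has been measured and on what is new or still open speak of the compounds shown alone.

Among the compounds with values here, compound 2 `Fc1ccc(C2=NN(C(=S)Nc3ccccc3)C(c3ccc4c(c3)OCCO4)C2)cc1` is one of two compounds measured so far in a functional assay on WM 266-4 cells (Homo sapiens) for antiproliferative activity, read by MTT assay, with a stated time of 48 h; on this read-out higher numbers stand for weaker inhibition of growth and lower numbers for stronger inhibition of growth. Compound 2 gives 22500 nM, the higher of the two numbers; compound 1 `S=C(Nc1ccccc1)N1N=C(c2ccccc2)CC1c1ccc2c(c1)OCCO2` gives 3180 nM. Within the data shown here, the single step that joins them, a 7.1-fold higher number from compound 1 to compound 2 (0.85 log units; beyond the scatter), is fluoro in place of hydrogen on an aromatic carbon, and it pushed the number upward by more than the scatter.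

Compound 3 `S=C(Nc1ccccc1)N1N=C(c2ccc(Cl)cc2)CC1c1ccc2c(c1)OCCO2` differs from compound 2 in one place: chloro in place of fluoro on an aromatic carbon, on an aromatic carbon of a six-membered aromatic ring of carbon only. Among the measured compounds shown here, no measured step exchanges one halogen for another, so there is no direct precedent. The step from compound 1 to compound 2 bears on it only indirectly, in showing that a change at this carbon can move the number by a modest amount. For the measured compounds named here, with that as the only guide, the expectation for compound 3 is a step that stays close to the scatter, with the direction uncertain, a 1.5-fold lower number from compound 2 to compound 3 (0.18 log units; within the scatter). The estimate for compound 3 is 15000 nM, expected to fall between 5000 nM and 50000 nM.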

Compound 3, concentration for 50% growth inhibition: > 200000 nM
Compound 3: no number, only a limit; the forecaster's own chance of this, stated with the estimate: 10%; middle value at least 13-fold (1.12 log units) from the limit.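

The entry for compound 3 is a limit of the assay and not a number: the limit of > 200000 nM in this assay, at which 1 of the 3 values shown sits. Even so, it shows that the choice of halogen at this carbon, para to a large group, matters in this assay: exchanging fluoro for chloro gives an at least 8.8-fold higher number from compound 2 to compound 3 (0.94 log units; beyond the scatter), and setting chloro in place of hydrogen gives an at least 62-fold higher number from compound 1 to compound 3 (1.79 log units; beyond the scatter). The earlier pair showed only that adding fluoro raises the number, whereas these steps show that the 4-fluorophenyl and 4-chlorophenyl compounds are not interchangeable, and that in these three compounds both halogens move the number the same way, with the hydrogen compound 1 giving the lowest number.

The true size of both new steps stays open, since each is bounded on one side only, and the compounds shown give no reason for the loss of growth inhibition. They also leave open what a methoxy group, an amine or a carboxylic acid at this carbon would do, and whether chloro would have the same effect on the other aromatic rings of the shared core.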